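The compounds below may be only part of what the source reports. "The series", "measured", "known", "first", "only" and "open" are said of these compounds alone.

Three compounds share one core and differ only in the groups on their second aromatic ring. In a functional assay on A549 cells (Homo sapiens) for antiproliferative activity, read by MTT assay, with a stated time of 72 h (on this read-out lower numbers stand for stronger inhibition and higher numbers for weaker inhibition), compound 1 `COc1cc(CCc2cccc(Cl)c2Cl)cc(OC)c1O` gives 3990 nM, the second highest of the three numbers. Compound 2 `COc1cc(CCc2cccc(F)c2)cc(OC)c1O` gives 2240 nM, which lies within the usual scatter of the number for compound 1, so the two cannot be told apart. Compound 3 `COc1cc(CCc2ccc(Cl)cc2)cc(OC)c1O` gives 22900 nM, a higher number than compound 1 and beyond the scatter. Compound 4 `COc1cc(CCc2ccccc2Cl)cc(OC)c1O` has not yet been tested in this assay . It differs from compound 1 in one place: hydrogen in place of chloro on an aromatic carbon. The expected step is a 1.3-fold higher number from compound 1 to compound 4 (0.10 log units; within the scatter), a shift that should stay within the scatter. Compound 4 is therefore estimated to give about 5000 nM, somewhere between 1500 nM and 16000 nM.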

Compound 4, half-maximal inhibitory concentration: 2130 nM
Compound 4: the middle estimate sits 2.3-fold (0.37 log units) above what was measured, within the range that was stated.
By their numbers in this assay, from the lowest: compounds 4, 2 and 1 (each within the scatter of the next); then compound 3.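

In this assay, hydrogen in place of the chloro group that sits ortho to a second chloro group gives a 1.9-fold lower number from compound 1 to compound 4 (0.27 log units; within the scatter), so compound 1 and compound 4 cannot be told apart. This chloro group is therefore not needed to keep the number at this level, at least while the other chloro group stays in place. Nothing shown offers a reason for this result. From the compounds shown here alone, whether a methoxy group, an amine or a carboxylic acid on this same aromatic carbon would give a similar number remains open.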